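Compound 3 to compound 4: methyl to nitro

This account rests on a few compounds, and the source may have more. Where it says the series, first, only, none or still open, it means among the compounds named here.

In a functional assay on HCT-15 cells (Homo sapiens) for antiproliferative activity, read by MTT assay, with a stated time of 72 h (a lower number here means a stronger inhibitor, a higher number a weaker inhibitor), compound 1 (`CCCCn1ccnc1-c1cc(OC)c(OC)c(OC)c1`) gives > 100000 nM, which is a limit. Compound 2 (`COc1cc(-c2nccn2Cc2ccccc2)cc(OC)c1OC`) gives > 100000 nM, also a limit. Within the data shown here, compound 3 (`COc1cc(-c2nccn2-c2cccc(C)c2)cc(OC)c1OC`) gives 1600 nM, the only actual number so far. Exchanging the group on the aromatic nitrogen gave large steps: an at least 62-fold lower number from compound 1 to compound 3 (1.79 log units; beyond the scatter) and an at least 62-fold lower number from compound 2 to compound 3 (1.79 log units; beyond the scatter). Compound 4 (`COc1cc(-c2nccn2-c2cccc([N+](=O)[O-])c2)cc(OC)c1OC`) keeps that aryl group and alters its substituent: nitro in place of methyl on an aromatic carbon. Among the measured compounds shown here, neither large step changes this substituent, so their size does not carry over, and no measured step covers this exchange. Only a small step is therefore expected in this assay, with a higher number slightly more likely than a lower one. The expected step is a 1.9-fold higher number from compound 3 to compound 4 (0.27 log units; within the scatter). For compound 4 the estimate is 3000 nM, with an expected range of 500 nM to 20000 nM.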

Compound 4, half-maximal inhibitory concentration: > 100000 nM
Compound 4 was reported as a limit; the forecaster's own chance of this, stated with the estimate: 10%; middle value at least 33-fold (1.52 log units) from the limit.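

Up to here, only the group on the aromatic nitrogen had been exchanged; this result shows that in this assay the substituent on the aromatic carbon also matters, as nitro in place of methyl gives an at least 62-fold higher number from compound 3 to compound 4 (1.79 log units; beyond the scatter). Keeping an aryl group on that nitrogen is therefore not enough for a readable number, and compound 3 remains the only one of the four that gives one. Compound 4 gives a limit, so the step is a minimum and its full size stays unknown: the limit of > 100000 nM in this assay, at which 3 of the 4 values shown sit.

Methyl and nitro alone cannot define a trend at this place. As far as these compounds go, whether an amine or a fluorine there would keep a number close to compound 3 at 1600 nM remains open.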